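Swapping Fluoro for Methyl on a Shared Cytotoxicity Read-out

A few compounds are considered here, and "the series" means these few. Any claim that something is new, unique, unknown or untested is made for them only; others in the source may bear on it.

Of the compounds shown here, three have been tested in an ADME assay on MT4 cells (Homo sapiens) for cytotoxicity, read by spectrophotometry, with a stated time of 5 days (on this read-out lower numbers stand for higher toxicity in this test and higher numbers for lower toxicity in this test), which asks how much of a substance it takes to harm human cells rather than how well it acts on a target. Compound 1 `CONC(=S)N/N=C1\C(=O)N(CN2CCN(c3ccc(OC)cc3)CC2)c2ccc(C)cc21` gives 324000 nM in this assay. Compound 3 `CONC(=S)N/N=C1\C(=O)N(CN2CCN(c3ccc(OC)cc3)CC2)c2ccc(F)cc21` shares its core with compound 1; in this assay compound 3 gives 276000 nM. The two differ by methyl in place of fluoro on an aromatic carbon, and the step of a 1.2-fold higher number from compound 3 to compound 1 (0.07 log units; within the scatter) shows that this exchange leaves the reading essentially unchanged.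

Compound 2 `CCN(CC)CN1C(=O)/C(=N\NC(=S)NO)c2cc(F)ccc21` is built on a different core; the difference between the two cores is not broken down here. In this assay compound 2 gives 521000 nM. Its value and those of compound 1 and compound 3 all lie within the scatter of one another, so none of the three can be singled out as harsher or gentler on the cells.

Compound 4 `CCN(CC)CN1C(=O)/C(=N\NC(=S)NO)c2cc(C)ccc21` has not yet been measured. It differs from compound 2 by methyl in place of fluoro on an aromatic carbon, the same change, at an identically described place, that turns compound 3 into compound 1. The earlier step of a 1.2-fold higher number from compound 3 to compound 1 (0.07 log units; within the scatter) was small, so for compound 2, which gives 521000 nM, the expected step of a 1.2-fold higher number from compound 2 to compound 4 (0.06 log units; within the scatter) is also small. Compound 4 is therefore estimated at 600000 nM in this assay, with a likely range from 350000 nM to 1000000 nM.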

Compound 4, half-maximal cytotoxic concentration: 534000 nM
Estimate against measurement, compound 4: 1.1-fold (0.05 log units) above, within the range that was stated.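

In this assay, putting methyl in place of fluoro on an aromatic carbon of the second core gives a 1.0-fold higher number from compound 2 to compound 4 (0.01 log units; within the scatter), so here too the exchange leaves the reading essentially unchanged. Set side by side, the two cases agree: the same change on two cores in this assay, a 1.2-fold higher number (0.07 log units; within the scatter) from compound 3 to compound 1 and a 1.0-fold higher number (0.01 log units; within the scatter) from compound 2 to compound 4, 1.1-fold (0.06 log units) apart, within the scatter of two such steps This shows only that, on these two cores, this one exchange at this one place makes no readable difference to the amount of substance needed to harm these cells; two pairs do not make a rule for other cores in the series, and as neither step lies beyond the scatter, they cannot show whether a clear shift in the reading would carry from one core to the other.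

The compounds shown carry only fluoro or methyl at this place, so it remains open whether a chloro group, a nitrile or a carboxylic acid there would also leave the reading unchanged. As far as these compounds go, it also remains open whether the same exchange would behave alike on another carbon of that aromatic ring, and whether the agreement holds for any read-out other than this cell test.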